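The source may report more compounds than this note shows. Statements on the series, on what has been measured and on what is new or still open speak of the compounds shown alone.

Compound 1 `CC(C)(C)c1ccc(NS(=O)(=O)c2ccc(N3CCNC3=O)cc2)cc1`: > 1000 nM
Compound 2 `O=C1NCCN1c1ccc(S(=O)(=O)Nc2ccc(F)c(F)c2)cc1`: 350 nM

Among the compounds with values here, in a functional assay on HT-29 cells (Homo sapiens) for antiproliferative activity, read by sulforhodamine B assay, with a stated time of 48 h (on this read-out higher numbers stand for weaker inhibition and lower numbers for stronger inhibition), compound 2 gives 350 nM, the only exact number so far. The reading for compound 1, > 1000 nM, is a limit and not a number. Compound 3 `O=C1NCCN1c1ccc(S(=O)(=O)Nc2ccc(Cl)cc2)cc1` carries 4-chlorophenyl in place of 3,4-difluorophenyl on a sulfonamide nitrogen. Within the data shown here, no measured pair tests this exchange, so only a small move toward weaker inhibition is expected in this assay, possibly no larger than the usual scatter. The expected change is a 1.4-fold higher number from compound 2 to compound 3 (0.15 log units; within the scatter). For compound 3, the estimate is 500 nM, with an expected range of 170 nM to 1500 nM.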

Compound 3, half-maximal inhibitory concentration: 220 nM
Compound 3: the middle estimate sits 2.3-fold (0.36 log units) above what was measured; the measured number falls inside the stated range.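

In this assay, 4-chlorophenyl in place of 3,4-difluorophenyl on a sulfonamide nitrogen gives a 1.6-fold lower number from compound 2 to compound 3 (0.20 log units; within the scatter), so these two aromatic groups cannot be told apart on this read-out. Chloro in place of tert-butyl on an aromatic carbon gives an at least 4.5-fold lower number from compound 1 to compound 3 (0.65 log units; beyond the scatter), the first step shown that lies beyond the scatter. The reading for compound 1 is a limit and not a number, so the full size of that step stays open: the limit of > 1000 nM in this assay, at which 1 of the 3 values shown sits.

The compounds shown leave open whether an amine or a carboxylic acid in place of the chloro would hold this level of inhibition.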